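Swapping naphthalen-2-yl for ethoxy on a carbonyl carbon

The compounds below may be only part of what the source reports. "The series", "measured", "known", "first", "only" and "open" are said of these compounds alone.

Measured so far in a functional assay on PC-3 cells (Homo sapiens) for inhibition, read by MTT assay, with a stated time of 48 h (a higher number here means a weaker inhibitor, a lower number a stronger inhibitor), are two compounds:
- Compound 1 `COc1cc(-c2nnc(SCc3ccc(F)cc3)n2-c2ccc(N(C)C)cc2)cc(OC)c1OC` gives 46500 nM here
- Compound 2 `COc1cc(-c2nnc(SCC(=O)c3ccc4ccccc4c3)n2-c2ccc(N(C)C)cc2)cc(OC)c1OC` gives 18100 nM here

Compound 2 stands lowest of these two numbers, which makes it the stronger inhibitor of the pair. For the measured compounds named here, one measured step bears on what follows: a 2.6-fold lower number from compound 1 to compound 2 (0.41 log units; beyond the scatter) is modest, and it came with (naphthalen-2-yl)carbonyl in place of 4-fluorophenyl. Compound 3 `CCOC(=O)CSc1nnc(-c2cc(OC)c(OC)c(OC)c2)n1-c1ccc(N(C)C)cc1` is still unmeasured. Its difference from compound 2 (ethoxy in place of naphthalen-2-yl on a carbonyl carbon) is ethoxy in place of naphthalen-2-yl on a carbonyl carbon, so (naphthalen-2-yl)carbonyl gives way to ethoxycarbonyl. Going by the values given here, no measured compound carries ethoxycarbonyl, so this single step is only a rough guide to size. Losing naphthalen-2-yl may undo that gain, so a modest rise in the number in this assay is expected. The expected size is a 2.2-fold higher number from compound 2 to compound 3 (0.34 log units; beyond the scatter) in this estimate. Compound 3 is estimated at 40000 nM in this test (expected range 14000 nM to 100000 nM).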

Compound 3, half-maximal inhibitory concentration: > 60000 nM
Compound 3 gave a limit, no number; the forecaster's own chance of this, stated with the estimate: 10%; middle value at least 1.5-fold (0.17 log units) from the limit.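

In this assay compound 3 gives a limit of the assay and not a number: the limit of > 60000 nM in this assay, at which 1 of the 3 values shown sits. On this carbonyl carbon, whose other neighbour is a saturated chain carbon, ethoxy takes the place of naphthalen-2-yl and removes its two aromatic rings, and the outcome is an at least 3.3-fold higher number from compound 2 to compound 3 (0.52 log units; beyond the scatter), so the carbonyl kept on its own does not hold the lower number of compound 2. From the compounds shown here alone, the comparison with the 4-fluorophenyl group gives an at least 1.2-fold higher number from compound 1 to compound 3 (0.11 log units; that floor lies within the scatter), and since that floor lies within the scatter, the true distance between these two compounds stays unknown.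

The compounds shown do not separate the loss of the two aromatic rings from the arrival of ethoxy, and a single phenyl ring on the same carbonyl carbon would help to tell how much of naphthalen-2-yl is needed to keep the lower number. Also open, going by these compounds, is how a free carboxylic acid, or an amide formed with a simple amine, would read at this carbonyl carbon in this assay.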